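A few compounds are considered here, and "the series" means these few. Any claim that something is new, unique, unknown or untested is made for them only; others in the source may bear on it.

Measured so far:
Compound 1 `COc1ccc(S(=O)(=O)N2CCc3cccc(NC(=O)c4ccccc4)c32)cc1`: 297 nM
Compound 2 `COc1ccc(S(=O)(=O)N2CCc3cccc(NS(=O)(=O)c4ccccc4)c32)cc1`: 650 nM

In a functional assay on KB cells (Homo sapiens) for cytotoxicity (a lower number here means a stronger inhibitor, a higher number a weaker inhibitor), compound 2 gives 650 nM, the higher of the two numbers and so the weaker result. The next compound, compound 3 `COc1ccc(S(=O)(=O)N2CCc3cccc(N)c32)cc1`, differs from it as follows: hydrogen in place of phenylsulfonyl on a nitrogen on an aromatic ring. Among the measured compounds shown here, only one measured step bears on this change, at the same nitrogen: a 2.2-fold higher number from compound 1 to compound 2 (0.34 log units; beyond the scatter). That modest step exchanged one group for another, whereas here the group is lost and only hydrogen remains, so it is a loose guide. For the measured compounds named here, no measured compound carries the plain amino group. A larger step towards a higher number is therefore expected, though with wide uncertainty. The expected change is a 2.8-fold higher number from compound 2 to compound 3 (0.44 log units; beyond the scatter). For compound 3, the estimated value is 1800 nM, with an expected range of 400 nM to 8000 nM.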

Compound 3, half-maximal inhibitory concentration: 2800 nM
Beside the measured number, compound 3's estimate is 1.6-fold (0.19 log units) below it; the measured number falls inside the stated range.
By their numbers in this assay, from the lowest: compound 1; then compound 2; then compound 3.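

In this assay, taking the phenylsulfonyl off the nitrogen to leave the plain amino group gives a 4.3-fold higher number from compound 2 to compound 3 (0.63 log units; beyond the scatter), and taking off the benzoyl gives a 9.4-fold higher number from compound 1 to compound 3 (0.97 log units; beyond the scatter). The earlier compounds shown here only compared two groups with each other; compound 3 adds the reference with hydrogen on this nitrogen, and both substituted compounds give lower numbers than it, with none of the three going against this. Nothing available here explains these steps.

The compounds shown leave open whether the lower numbers depend on the phenyl ring at all or would also come with an acetyl or a methanesulfonyl group on this nitrogen. Also open, from the compounds shown here alone, is how a phenylacetyl group or a benzoyl carrying a methoxy group would compare with compound 1.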